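The source may hold more compounds than are shown below. What is called first, only, known or untested is meant among the compounds shown, and "the series" means these compounds.

Compound 1: `CN(C[C@H]1Cc2c(cccc2N2CCN(Cc3ccccn3)CC2)CN1)[C@H]1CCCc2cccnc21`, 4.47 nM. Compound 2: `CN(C[C@H]1Cc2c(cccc2N2CCN(c3cccc(C(F)(F)F)c3)CC2)CN1)[C@H]1CCCc2cccnc21`, > 16700 nM.

Both compounds were tested in a functional assay on CCRF-CEM cells for antagonist activity at C-X-C chemokine receptor type 4 (Homo sapiens), read by calcium flux, with stated times of 25 min and 90 s; a lower number here means a stronger inhibitor, a higher number a weaker inhibitor. Compound 1 gives 4.47 nM. For compound 2 the result is a limit rather than a number, > 16700 nM, so where compound 2 truly stands is known only as being at or past that edge (the limit of > 16700 nM in this assay, at which 1 of the 2 values shown sits). Going by the values given here, the single measured step, an at least 3700-fold higher number from compound 1 to compound 2 (3.57 log units; beyond the scatter), shows that the group on the ring nitrogen of the shared core can move the number a long way.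

Compound 3, `CN(C[C@H]1Cc2c(cccc2N2CCN(c3ccccn3)CC2)CN1)[C@H]1CCCc2cccnc21`, has not been measured. It differs from compound 2 by pyridin-2-yl in place of 3-(trifluoromethyl)phenyl on an amine nitrogen in a ring. This brings back a pyridine ring of the kind seen in compound 1, but without the methylene that links that ring to the nitrogen in compound 1, so the measured step is only an imperfect guide. Given the size of the step from compound 1 to compound 2, a large move back toward lower numbers is expected, though a remaining gap to compound 1 is plausible. Compound 3 is estimated at 400 nM, with a range from 40 nM to 8000 nM, which is expected to correspond to an at least 41-fold lower number from compound 2 to compound 3 (1.62 log units; beyond the scatter).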

Compound 3, half-maximal inhibitory concentration: 17.9 nM
Compound 3: the middle estimate sits 22-fold (1.35 log units) above what was measured; the whole stated range lies above it.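

In this assay, pyridin-2-yl in place of 3-(trifluoromethyl)phenyl on the same amine nitrogen gives an at least 930-fold lower number from compound 2 to compound 3 (2.96 log units; beyond the scatter), so an aromatic ring attached straight to that nitrogen is compatible with a low number. Pyridin-2-yl in place of (pyridin-2-yl)methyl gives a 4.0-fold higher number from compound 1 to compound 3 (0.60 log units; beyond the scatter), a modest step, which shows that the methylene link is not required for a low number, although losing it does change the result beyond the scatter. The value of compound 2 is a limit rather than a number, so the true size of the first of these steps remains unknown: the limit of > 16700 nM in this assay, at which 1 of the 3 values shown sits.

The change from compound 2 to compound 3 swaps a ring carbon for a ring nitrogen and removes the trifluoromethyl group at once, so the compounds shown leave open which of the two accounts for the step. An unsubstituted phenyl on that nitrogen would separate the two, while a benzyl group or a longer chain such as 2-(pyridin-2-yl)ethyl would test how the link itself affects the number.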